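Swapping cyclohexyl for 4-ethylphenyl on a dimethylamino analogue

The source may report more compounds than this note shows. Statements on the series, on what has been measured and on what is new or still open speak of the compounds shown alone.

Compound 1 `CN1C(=S)N(C2CCCCC2)C(=O)/C1=C/c1cccc(O)c1O`: 6350 nM
Compound 2 `CN1C(=S)N(C2CCCCC2)C(=O)/C1=C/c1ccc(N(C)C)cc1`: 35600 nM
Compound 3 `CCc1ccc(N2C(=O)/C(=C/c3cccc(O)c3O)N(C)C2=S)cc1`: 26400 nM

In an assay for inhibition of NADPH oxidase 4 (Homo sapiens), read by chemiluminescence (a lower number here means a stronger inhibitor, a higher number a weaker inhibitor), compound 2 gives the highest number of the three, beyond the scatter from compound 1 but within the scatter of compound 3. Compound 4 `CCc1ccc(N2C(=O)/C(=C/c3ccc(N(C)C)cc3)N(C)C2=S)cc1` has not yet been measured. It differs from compound 2 by 4-ethylphenyl in place of cyclohexyl on an amide-type nitrogen in a ring. The same change has been measured once before, on a different aryl partner: a 4.2-fold higher number from compound 1 to compound 3 (0.62 log units; beyond the scatter). On that basis a rise of similar size is expected for compound 4, so a step of a 3.4-fold higher number from compound 2 to compound 4 (0.53 log units; beyond the scatter) is estimated. Compound 4 is expected to give about 120000 nM, with a likely range from 35000 nM to 400000 nM, because the number for compound 2 35600 nM is already high.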

Compound 4, inhibition constant: 2630 nM
Beside the measured number, compound 4's estimate is 46-fold (1.66 log units) above it; the measured number lies below the stated range.
By their numbers in this assay, from the lowest: compound 4; then compound 1; then compounds 3 and 2 (each within the scatter of the next).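

In this assay, 4-ethylphenyl in place of cyclohexyl gives a 14-fold lower number from compound 2 to compound 4 (1.13 log units; beyond the scatter), so this position does not respond in one fixed direction. What the change does here depends on the rest of the molecule, and the two measured pairs move in opposite directions: the same change on two cores in this assay, a 4.2-fold higher number (0.62 log units; beyond the scatter) from compound 1 to compound 3 and a 14-fold lower number (1.13 log units; beyond the scatter) from compound 2 to compound 4, 56-fold (1.75 log units) apart, beyond the scatter of two such steps

Two pairs cannot show which feature of the aryl partner decides the direction, the dimethylamino group or the two hydroxyl groups. Also open, as far as these compounds go, is how a benzyl group or a longer alkyl chain on this nitrogen would behave on either core.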